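The source may report more compounds than this note shows. Statements on the series, on what has been measured and on what is new or still open speak of the compounds shown alone.

Compound 2 `CN1CC[C@H](c2ccc(Cl)cc2)[C@@H](CC(=O)N(C)C)C1` gives the lowest number of the two measured compounds in an assay on striatum with sodium-dependent dopamine transporter (Rattus norvegicus) as the target (a lower number here means a stronger inhibitor, a higher number a weaker inhibitor), at 16 nM, while compound 1 `C=CCOC[C@H]1CN(C)CC[C@@H]1c1ccc(Cl)cc1` gives 60 nM. Going by the values given here, the one measured step, a 3.8-fold lower number from compound 1 to compound 2 (0.57 log units; beyond the scatter), replaced allyloxy with dimethylcarbamoyl on a chain carbon. Among the compounds with values here, compound 3 `COC(=O)/C=C/[C@H]1CN(C)CC[C@@H]1c1ccc(Cl)cc1` carries 2-(methoxycarbonyl)ethenyl in place of (dimethylcarbamoyl)methyl on a saturated ring carbon, a change that no measured step covers exactly. The related step was modest, so only a small shift is expected here, most likely a slightly higher number. Compound 3 is therefore estimated at 30 nM in this assay, between 8 nM and 120 nM. That estimate means a 1.9-fold higher number from compound 2 to compound 3 (0.27 log units; within the scatter).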

Compound 3, inhibition constant: 53 nM
The estimate for compound 3 lay 1.8-fold (0.25 log units) below the measured number; the range from low to high includes it.
By their numbers in this assay, from the lowest: compound 2; then compounds 3 and 1 (each within the scatter of the next).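

In this assay, putting 2-(methoxycarbonyl)ethenyl in place of (dimethylcarbamoyl)methyl on this saturated ring carbon gives a 3.3-fold higher number from compound 2 to compound 3 (0.52 log units; beyond the scatter), so the lower number of compound 2 does not carry over to this other chain. Set against (allyloxy)methyl, the same group gives a 1.1-fold lower number from compound 1 to compound 3 (0.05 log units; within the scatter), which leaves those two groups indistinguishable here. No measured evidence explains either step. The compounds shown leave open which part of the change matters, as the chain's length, double bond and end group all differ. A saturated ester chain or a carboxylic acid at this position remains an open case.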